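Trimming the chain on the core of compound 3 to a hydrogen

The compounds below may be only part of what the source reports. "The series", "measured", "known", "first", "only" and "open" are said of these compounds alone.

Measured compounds:
- compound 1, `Cc1nc(-c2ccc(F)cc2)c(C(=O)N2CCN(c3cccc(Cl)c3)CC2)o1`: 40.1 nM
- compound 2, `CCc1nc(-c2ccc(OC)c(OC)c2)c(C(=O)N2CCN(c3cccc(Cl)c3)CC2)o1`: "not active" (no number reported)
- compound 3, `CCCc1nc(-c2ccc(OC)c(OC)c2)c(C(=O)N2CCN(c3cccc(Cl)c3)CC2)o1`: "not active" (no number reported)

In a functional assay on HL-60 cells (Homo sapiens) for inhibition, read by MTT assay, with a stated time of 72 h (on this read-out higher numbers stand for weaker inhibition and lower numbers for stronger inhibition), compound 3 is reported only as "not active" (no number reported), without a number. Compound 2 is reported the same way, as "not active" (no number reported). Going by the values given here, compound 1 differs from both in more than one place and gives 40.1 nM, so no single step between measured compounds can be drawn.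

Compound 4, `COc1ccc(-c2nc(C)oc2C(=O)N2CCN(c3cccc(Cl)c3)CC2)cc1OC`, is reached from compound 3 by one change: hydrogen in place of ethyl on a saturated chain carbon bound to an aromatic carbon. Compound 4 thus carries the methyl seen on the core of compound 1, while keeping the aryl group shared with compounds 2 and 3, both of which were inactive. Because compound 2 gives "not active" (no number reported) and compound 3 gives "not active" (no number reported), the aryl group they share with compound 4 gives no ground for confidence, and the direction of the step from compound 3 to compound 4 cannot be fixed from the data. Compound 4 is expected to give 5000 nM in this assay, within a wide range from 300 nM to 50000 nM, with a fair chance that it too comes back without a number.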

Compound 4, half-maximal inhibitory concentration: "not active" (no number reported)
No number was reported for compound 4, and the estimate cannot be compared.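

Compound 3 and compound 4 are both reported as not active in this assay without a number, and no step can be read between them. No measurement shown offers an explanation. On these data alone, what sets compound 1 at 40.1 nM apart from compound 2, compound 3 and compound 4 stays open.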